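Aryl substituent exchange on the shared core

The compounds below may be only part of what the source reports. "The series", "measured", "known", "first", "only" and "open" are said of these compounds alone.

Three compounds of the series have numbers in an assay on HEK-293T cells for displacement of a labelled ligand from corticotropin-releasing factor receptor 1 (Homo sapiens), read by scintillation counting, with a stated time of 2 h; a lower number here means a stronger inhibitor, a higher number a weaker inhibitor. Compound 1 `CCCCN(CC)c1cc(C)nc2c1NC(=O)CN2c1ccc(C(C)(C)C)cc1Br` gives 4.2 nM. Compound 2 `CCCCN(CC)c1cc(C)nc2c1NC(=O)CN2c1ccc(C)cc1Cl` gives 4.4 nM. Compound 3 `CCN(C)c1cc(C)nc2c1N(CCCCF)C(=O)CN2c1ccc(C(C)C)cc1Br`, which differs from the other two in several places at once, gives 13.9 nM. Compound 2 thus holds the second highest of the three numbers: compound 1 lies within the scatter of it, so no order between the two can be claimed, while compound 3 gives a higher number by a margin beyond the scatter. For the measured compounds named here, no pair among the three differs in only one place, so no single step between measured compounds is available.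

Compound 4 `CCCCN(CC)c1cc(C)nc2c1NC(=O)CN2c1ccc(Cl)cc1Cl` has not been measured. It differs from compound 2 by chloro in place of methyl on an aromatic carbon; cut one bond further out, the change reads 2-chloro-4-methylphenyl to 2,4-dichlorophenyl. The measured set contains no exchange of this kind, so nothing among compounds 1 to 3 shows its effect. The expected step of a 1.1-fold higher number from compound 2 to compound 4 (0.06 log units; within the scatter) is therefore estimated as small, in no firm direction, and not beyond the scatter. Compound 4 is expected to give about 5 nM in this assay, within a range from 2 nM to 13 nM.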

Compound 4, inhibition constant: 3.4 nM
The estimate for compound 4 lay 1.5-fold (0.17 log units) above the measured number; measured number inside the range.
By their numbers in this assay, from the lowest: compounds 4, 1 and 2 (each within the scatter of the next); then compound 3.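

In this assay, chloro in place of methyl on an aromatic carbon, meta to a chloro group and para to a large group, gives a 1.3-fold lower number from compound 2 to compound 4 (0.11 log units; within the scatter). For the compounds shown here, this is the first step between compounds that differ in one place, and it lies within the scatter, so this read-out does not separate the 2-chloro-4-methylphenyl and 2,4-dichlorophenyl groups on this core. For this one pair, a methyl and a chloro group at this position give numbers that cannot be ordered, and no measurement at hand bears on why.

From the compounds shown here alone, whether this tolerance extends beyond these two single-atom groups remains open: a methoxy group, a primary amine or a carboxylic acid at the same position could give a step of quite different size. Going by these compounds, it is also open whether the exchange of methyl for chloro reads the same on a compound with a different amine side chain or with a 4-fluorobutyl chain on the amide nitrogen, as in compound 3.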